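Hydroxy in place of fluoro: notes on compound 3

A few compounds are considered here, and "the series" means these few. Any claim that something is new, unique, unknown or untested is made for them only; others in the source may bear on it.

Measured so far in a functional assay on HeLa cells (Homo sapiens) for inhibition, read by trypan blue exclusion, with a stated time of 72 h; a higher number here means a weaker inhibitor of growth, a lower number a stronger inhibitor of growth:
- compound 1 (`Cn1c(=O)c(S(=O)(=O)c2ccc(OC(=O)CCCCC3SCC4NC(=O)NC43)cc2)cc2cnc(Nc3ccc4[nH]ccc4c3)nc21`): 500 nM
- compound 2 (`Cn1c(=O)c(S(=O)(=O)c2ccc(F)cc2)cc2cnc(Nc3ccc4[nH]ccc4c3)nc21`): 75 nM

Compound 2 holds the lower number of the two in this assay and is thus the stronger growth inhibitor, with compound 1 higher by a gap beyond the usual scatter. Compound 3 (`Cn1c(=O)c(S(=O)(=O)c2ccc(O)cc2)cc2cnc(Nc3ccc4[nH]ccc4c3)nc21`) departs from compound 2 in one place: hydroxy in place of fluoro on an aromatic carbon with hydroxy in place of fluoro on an aromatic carbon, para to a large group. For the measured compounds named here, no measured step covers this change, so the data offer only the two values as a guide. Compound 2 at 75 nM serves as the anchor for the expectation. The expected 1.7-fold higher number from compound 2 to compound 3 (0.24 log units; within the scatter) points toward a higher number and is small enough to stay within the scatter. Compound 3 is estimated at 130 nM with an expected range from 40 nM to 420 nM.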

Compound 3, concentration for 50% growth inhibition: 750 nM
Estimate against measurement, compound 3: 5.8-fold (0.76 log units) below; measured number above the stated range.
By their numbers in this assay, from the lowest: compound 2; then compounds 1 and 3 (each within the scatter of the next).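

In this assay the change from 4-fluorophenyl to 4-hydroxyphenyl, para to a large group, costs clear growth-inhibitory strength (a 10-fold higher number from compound 2 to compound 3 (1.00 log units; beyond the scatter)), so this position is sensitive to the exchange of fluoro for hydroxy. For the compounds shown here, this is the first single-place step, and it places compound 3 within the scatter of compound 1, leaving compound 2 alone with the lowest number of the three. No measurement at hand explains the size of this step.

On these data alone, it remains open whether fluoro is itself favourable here or hydroxy is unfavourable, a question that plain hydrogen at this position would help to settle. As far as these compounds go, the response to a methoxy group, a chloro group, an amine or a carboxylic acid on the same aromatic carbon also remains open.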